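The source may report more compounds than this note shows. Statements on the series, on what has been measured and on what is new or still open speak of the compounds shown alone.

Working notes on the spiro series. All four members share one core, differing only in the aryl group on the aromatic nitrogen of the triazole, and are compared in an ADME assay on HUVEC cells (Homo sapiens) for antiproliferative activity, read by MTT assay, with a stated time of 48 h; on this read-out higher numbers stand for weaker inhibition and lower numbers for stronger inhibition.

Compound 1, `Cc1cc(C)cc(-n2nncc2CN2C(=O)C3(C(C#N)=C(N)Oc4c3c3nc5ccccc5nc3c3ccccc43)c3ccccc32)c1`, returns in this assay only a limit, > 50000 nM. Compound 2, `N#CC1=C(N)Oc2c(N)cc3nc4ccccc4nc3c2C12C(=O)N(Cc1cnnn1-c1ccccc1Br)c1ccccc12`, gives 34200 nM in this assay. Compound 3, `COc1ccc(-n2nncc2CN2C(=O)C3(C(C#N)=C(N)Oc4c(N)cc5nc6ccccc6nc5c43)c3ccccc32)cc1`, again returns only a limit in this assay, > 50000 nM.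

Going by the values given here, the one step that can be measured, an at least 1.4-fold higher number from compound 2 to compound 3 (0.16 log units; that floor lies within the scatter), is a change of the aryl group alone, and its floor sits within the scatter. Compound 3 therefore stands at the weak end of what has been measured, at the point described by the limit of > 50000 nM in this assay, at which 2 of the 3 values shown sit, and cannot be placed more precisely than that.

Compound 4, `N#CC1=C(N)Oc2c(N)cc3nc4ccccc4nc3c2C12C(=O)N(Cc1cnnn1-c1c(F)cccc1F)c1ccccc12`, is the next variant: 2,6-difluorophenyl in place of 4-methoxyphenyl on an aromatic nitrogen. Among the compounds with values here, the only step that bears on it is the one from compound 2 to compound 3, which also exchanged the aryl group on the aromatic nitrogen and left the read-out essentially where it was. No step beyond the scatter is therefore expected in this assay, and the step of an at least 1.1-fold lower number from compound 3 to compound 4 (0.04 log units; that floor lies within the scatter) is estimated to stay within it. Compound 4 is expected to give about 45000 nM in this assay, within 18000 nM to 110000 nM, with a fair chance that only a limit is returned.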

Compound 4, half-maximal inhibitory concentration: > 50000 nM
Compound 4 gave a limit, no number; the forecaster's own chance of this, stated with the estimate: 55%; at least 1.1-fold (0.04 log units) between middle value and limit.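

With 2,6-difluorophenyl on the aromatic nitrogen of the triazole, compound 4 also returns only a limit in this assay, so a fluorine-bearing aryl group at this position gives no number, whereas the 2-bromophenyl group of compound 2 does give one. This does not separate the two groups, since the exchange gives an at least 1.4-fold higher number from compound 2 to compound 4 (0.16 log units; that floor lies within the scatter), and a floor within the scatter supports no claim that the 2-bromophenyl group is better than the 2,6-difluorophenyl group. The step between the two limits of compound 3 and compound 4 cannot be read, and the methoxy-bearing and fluorine-bearing aryl groups cannot be ranked, leaving the series gathered at one point: the limit of > 50000 nM in this assay, at which 3 of the 4 values shown sit.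

The compounds shown leave open whether any group on this nitrogen can bring the read-out clearly beyond the scatter from compound 2, since every group here is a substituted phenyl. An unsubstituted phenyl, a phenyl carrying an amine or a carboxylic acid, or a benzyl group or longer alkyl chain in place of the aryl group would test whether this position matters at all.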